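The source may report more compounds than this note shows. Statements on the series, on what has been measured and on what is new or still open speak of the compounds shown alone.

Measured so far:
- compound 1, `CC1=CC[C@H](C(C)(C)NC(=S)N/N=C/c2ccccc2)CC1` — > 100000 nM
- compound 2, `CC1=CC[C@H](C(C)(C)NC(=S)N/N=C/c2cccc([N+](=O)[O-])c2)CC1` — > 100000 nM

In a functional assay on NCI/ADR-RES cells (Homo sapiens) for inhibition, read by sulforhodamine B assay, with a stated time of 48 h (on this read-out lower numbers stand for stronger inhibition of growth and higher numbers for weaker inhibition of growth), compound 1 gives only a limit, > 100000 nM. Compound 2 likewise gives only a limit, > 100000 nM. The step that the two limits leave unreadable from compound 1 to compound 2 is therefore unreadable, as both sit at the limit of > 100000 nM in this assay, at which 2 of the 2 values shown sit.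

Compound 3, `CC1=CC[C@H](C(C)(C)NC(=S)N/N=C/c2cccs2)CC1`, is not yet measured and differs from compound 1 by thiophen-2-yl in place of phenyl on a carbon with a double bond to nitrogen. For the measured compounds named here, no measured step bears on this change, and compound 1 itself stands only at a limit. Compound 3 is expected to stay near that limit, with a number no higher from compound 1 to compound 3 (the limit leaves the size open) as the estimated step. The estimate for compound 3 is 100000 nM, between 30000 nM and 300000 nM.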

Compound 3, concentration for 50% growth inhibition: 13600 nM
Compound 3: middle estimate off by 7.4-fold (0.87 log units), on the high side; the whole stated range lies above it.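

In this assay, the ring on the carbon with a double bond to nitrogen proves able to change the result: thiophen-2-yl in place of phenyl gives an at least 7.3-fold lower number from compound 1 to compound 3 (0.86 log units; beyond the scatter). The earlier step, nitro in place of hydrogen on an aromatic carbon, cannot be read. Compound 3 is the only compound shown with a measured number rather than a limit: the limit of > 100000 nM in this assay, at which 2 of the 3 values shown sit.

The compounds shown do not separate the effect of the sulfur from that of the five-membered ring. A furan-2-yl or pyridin-2-yl ring at this place could help to tell these apart.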